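Sulfur substituent swap on the cinnamide series

The source may report more compounds than this note shows. Statements on the series, on what has been measured and on what is new or still open speak of the compounds shown alone.

Compound 1 `Nc1ccccc1NC(=O)/C=C/c1ccc(CSc2ccc(F)cc2)cc1`: 3670 nM
Compound 2 `Cc1ccc(SCc2ccc(C(=O)Nc3ccccc3N)cc2)cc1`: 3700 nM
Compound 3 `Nc1ccccc1NC(=O)/C=C/c1ccc(CSc2cccc3ccccc23)cc1`: "not determined" (no result reported)

These values come from a functional assay on A-375 cells (Homo sapiens) for antiproliferative activity, read by CCK-8 assay, with a stated time of 72 h; on this read-out higher numbers stand for weaker inhibition and lower numbers for stronger inhibition. Compound 3 has no number in this assay, so it gives no starting value, and the data place it neither above nor below the other compounds. Compound 4 `CC(C)(C)c1ccc(SCc2ccc(/C=C/C(=O)Nc3ccccc3N)cc2)cc1` remains unmeasured. The structural change is 4-(tert-butyl)phenyl in place of naphthalen-1-yl on a sulfur, with 4-(tert-butyl)phenyl in place of naphthalen-1-yl on a sulfur. Among the measured compounds shown here, no measured step shows what such a swap does. The expected reference is therefore compound 1 at 3670 nM, which shares the core of compound 4, and no shift beyond the scatter in either direction is expected from it. The estimate for compound 4 is 3000 nM, with an expected range of 1000 nM to 9000 nM.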

Compound 4, half-maximal inhibitory concentration: 1550 nM
Estimate against measurement, compound 4: 1.9-fold (0.29 log units) above; measured number inside the range.
By their numbers in this assay, from the lowest: compound 4; then compounds 1 and 2 (each within the scatter of the next).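

In this assay, tert-butyl in place of fluoro on an aromatic carbon gives a 2.4-fold lower number from compound 1 to compound 4 (0.37 log units; beyond the scatter), so the group carried on the sulfur can move this read-out beyond the scatter. Among the compounds shown here, this is the only readable step at this place; the swap from naphthalen-1-yl to 4-(tert-butyl)phenyl cannot be read, since compound 3 has no number. No evidence bears on why the number falls. Still open, from the compounds shown here alone, is how an amine or a carboxylic acid on that aromatic carbon would read.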